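Removing a chloro group on a fused two-ring core

The source may report more compounds than this note shows. Statements on the series, on what has been measured and on what is new or still open speak of the compounds shown alone.

Three compounds have been measured in a functional assay on SF-268 cells (Homo sapiens) for cytotoxicity, read by sulforhodamine B assay, with a stated time of 48 h; on this read-out lower numbers stand for stronger inhibition of growth and higher numbers for weaker inhibition of growth:
Compound 1, `ClCc1ccccc1Cn1cnc2c(Cl)nc(Cl)nc21`, gives 4160 nM.
Compound 2, `ClCc1ccccc1Cn1cnc2c(Cl)ncnc21`, gives 10900 nM.
Compound 3, `ClCc1ccc(Cn2cnc3nc(Cl)nc(Cl)c32)cc1`, gives 3980 nM.

Compound 2 is compound 1 with the change (hydrogen in place of chloro on an aromatic carbon), and this step changed the read-out by a 2.6-fold higher number from compound 1 to compound 2 (0.42 log units; beyond the scatter). Compound 3 has the same atoms as compound 1 joined differently; the difference between the two cores is not broken down here. Compound 4, `ClCc1ccc(Cn2cnc3ncnc(Cl)c32)cc1`, has not yet been measured. It is compound 3 with the change (hydrogen in place of chloro on an aromatic carbon), the same change that separates compound 1 from compound 2. Because the earlier step was a 2.6-fold higher number from compound 1 to compound 2 (0.42 log units; beyond the scatter), compound 4 is expected to give a higher number than compound 3, by about a 2.5-fold higher number from compound 3 to compound 4 (0.40 log units; beyond the scatter). The estimate for compound 4 in this assay is 10000 nM, with a likely range from 5000 nM to 20000 nM.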

Compound 4, concentration for total growth inhibition: 3380 nM
The estimate for compound 4 lay 3.0-fold (0.47 log units) above the measured number, and the stated range ends above it.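

In this assay, hydrogen in place of chloro on the core of compound 3 gave a 1.2-fold lower number from compound 3 to compound 4 (0.07 log units; within the scatter), so this pair cannot be told apart. The same replacement therefore did not carry over from one core to the other: the same change on two cores in this assay, a 2.6-fold higher number (0.42 log units; beyond the scatter) from compound 1 to compound 2 and a 1.2-fold lower number (0.07 log units; within the scatter) from compound 3 to compound 4, 3.1-fold (0.49 log units) apart, beyond the scatter of two such steps

This shows that the size of the step on the core of compound 1 cannot be assumed on the core of compound 3, but two pairs do not show why the cores differ or how the change would behave on a further core. The compounds shown leave open how an amine or a methoxy group on that aromatic carbon, between two ring nitrogen atoms, would read on either core. They also leave open what an amine would do in place of the remaining chloro group.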